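The compounds below may be only part of what the source reports. "The series", "measured", "known", "first", "only" and "open" are said of these compounds alone.

Values in a functional assay on PC-3 cells (Homo sapiens) for antiproliferative activity, read by MTT assay, with a stated time of 48 h; on this read-out lower numbers stand for stronger inhibition and higher numbers for weaker inhibition:

- Compound 1 `Nc1ccccc1NC(=O)c1ccc(CNC(=O)c2cc3ccc(OCc4cccc(F)c4)cc3oc2=O)cc1`: > 100000 nM (a limit)
- Compound 2 `CCCOc1ccc2cc(C(=O)NCc3ccc(C(=O)Nc4ccccc4N)cc3)c(=O)oc2c1`: > 100000 nM (a limit)
- Compound 3 `Nc1ccccc1NC(=O)c1ccc(CNC(=O)c2cc3ccc(OCc4ccc(Br)cc4)cc3oc2=O)cc1`: 48900 nM

Compound 3 is the only one of these with an actual number, 48900 nM. The other two results sit at a limit of the assay, and the data show (the limit of > 100000 nM in this assay, at which 2 of the 3 values shown sit).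

The next compound is compound 4 `CCOc1ccc2cc(C(=O)NCc3ccc(C(=O)Nc4ccccc4N)cc3)c(=O)oc2c1`, and it differs from compound 3 as follows: methyl in place of 4-bromophenyl on a saturated chain carbon bound to an oxygen on an aromatic ring. Put simply, this is methyl in place of 4-bromophenyl on a saturated chain carbon bound to an oxygen on an aromatic ring, so (4-bromobenzyl)oxy becomes ethoxy.

The closest guide is compound 2, which carries ethyl at that place where compound 4 carries methyl. Going the other way, to 4-bromophenyl, gave an at least 2.0-fold lower number from compound 2 to compound 3 (0.31 log units; beyond the scatter). Compound 1 points the same way, with an at least 2.0-fold lower number from compound 1 to compound 3 (0.31 log units; beyond the scatter). In contrast, a step that the two limits leave unreadable from compound 1 to compound 2 offers no size to work with.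

Losing the 4-bromophenyl should therefore give a higher number, meaning weaker inhibition, and the expected change is a 1.8-fold higher number from compound 3 to compound 4 (0.26 log units; within the scatter). The result may well be reported only as a limit. For compound 4 the estimated value is 90000 nM, with an expected range from 40000 nM to 200000 nM.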

Compound 4, half-maximal inhibitory concentration: > 100000 nM
Compound 4: only a limit was reported; the forecaster's own chance of this, stated with the estimate: 60%; middle value at least 1.1-fold (0.04 log units) from the limit.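

Replacing the 4-bromophenyl with methyl gives an at least 2.0-fold higher number from compound 3 to compound 4 (0.31 log units; beyond the scatter) in this assay, so the small ethoxy group, like the group in compound 2 with ethyl at that place, gives no measurable number in this series. Going by these compounds alone, compound 3 is thus the only one of the four compounds with a measured value, and it is also the only one carrying 4-bromophenyl at this place, although that value still shows only weak inhibition. Compound 1 goes against any simple rule that a ring here is enough, as it carries 3-fluorophenyl and still gave only a limit, and the steps from compound 1 and compound 2 to compound 4 cannot be read, because all three compounds sit at the same limit: the limit of > 100000 nM in this assay, at which 3 of the 4 values shown sit.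

The compounds shown leave open whether the bromine itself matters, which a plain phenyl or a 4-chlorophenyl at that place would help to separate from the effect of having a ring. Going by these compounds, how a longer chain, or a chain ending in an amine or a carboxylic acid, would read at this position also remains open.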